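The compounds below may be only part of what the source reports. "The series", "measured", "known", "first", "only" and "open" are said of these compounds alone.

The measured compounds, with the structure of each:

compound 1, `O=C(Nc1cccc(-c2oc3cc(-c4ccc(F)cc4)ccc3c(=O)c2O)c1)c1ccccc1F`, 10800 nM;
compound 2, `Cc1ccc(C(=O)Nc2cccc(-c3oc4cc(-c5ccc(F)cc5)ccc4c(=O)c3O)c2)cc1`, 7110 nM;
compound 3, `O=C(Nc1cccc(-c2oc3cc(-c4ccc(F)cc4)ccc3c(=O)c2O)c1)c1ccc(Cl)cc1`, 4030 nM.

All three share one core and differ only in the aryl group on the carbonyl carbon of the amide. In a functional assay on HCC1937 cells (Homo sapiens) for antiproliferative activity, read by CCK-8 assay, with a stated time of 72 h (on this read-out higher numbers stand for weaker inhibition and lower numbers for stronger inhibition), compound 2 stands second highest of the three numbers: compound 1 is its nearest neighbour, and the step of a 1.5-fold lower number from compound 1 to compound 2 (0.18 log units; within the scatter) lies within the scatter; compound 3 lies furthest from it, yet the step of a 1.8-fold lower number from compound 2 to compound 3 (0.25 log units; within the scatter) also stays within the scatter. Going by the values given here, the only step beyond the scatter is a 2.7-fold lower number from compound 1 to compound 3 (0.43 log units; beyond the scatter), and that one is modest.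

Compound 4, `Cc1cccc(C(=O)Nc2cccc(-c3oc4cc(-c5ccc(F)cc5)ccc4c(=O)c3O)c2)c1`, has not been measured in this assay. It differs from compound 2 by 3-methylphenyl in place of 4-methylphenyl on a carbonyl carbon. Among the compounds with values here, no measured pair moves a methyl from one aromatic carbon to another; the steps that bear on the question are those altering the aryl group on the carbonyl carbon, and each was small or modest. The step of a 1.0-fold lower number from compound 2 to compound 4 (0.01 log units; within the scatter) is therefore expected to stay within the scatter, with no direction favoured. Compound 4 is estimated at 7000 nM, in the range 3500 nM to 14000 nM.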

Compound 4, half-maximal inhibitory concentration: 8030 nM
Estimate against measurement, compound 4: 1.1-fold (0.06 log units) below, and the stated range covers the measured number.
By their numbers in this assay, from the lowest: compounds 3, 2, 4 and 1 (each within the scatter of the next, the first and the last beyond it).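

In this assay, going by these compounds alone, the 3-methylphenyl in place of 4-methylphenyl on the carbonyl carbon gives a 1.1-fold higher number from compound 2 to compound 4 (0.05 log units; within the scatter) and so provides the first measured pair in which one group differs only in where it sits on this aryl ring, with no separation between the two compounds. Within the data shown here, the other new steps, a 2.0-fold higher number from compound 3 to compound 4 (0.30 log units; within the scatter) and a 1.3-fold lower number from compound 1 to compound 4 (0.13 log units; within the scatter), also stay within the scatter, so compound 1 and compound 3 remain the only pair set apart beyond it. Nothing available explains why moving the methyl leaves the number within the scatter.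

The compounds shown leave open whether moving a chloro around this aryl ring would behave as moving the methyl did. They also leave open whether an amine, a carboxylic acid or a longer chain on the carbonyl carbon would give a step beyond the scatter.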